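A 5-methyl-1,3,4-thiadiazol-2-yl analogue of compound 2

This account rests on a few compounds, and the source may have more. Where it says the series, first, only, none or still open, it means among the compounds named here.

Measured compounds:
Compound 1, `N#Cc1ccc(-c2cs/c(=N/NC(=O)CSc3ncccn3)n2-c2ccccc2)cc1`, in an ADME assay on NIH3T3 cells (Mus musculus) for cytotoxicity, read by MTT assay, with a stated time of 24 h (a lower number here means a stronger inhibitor, a higher number a weaker inhibitor), is reported only as a limit, < 3.9 ug/mL.
Compound 2, `Cn1cnnc1SCC(=O)N/N=c1/scc(-c2ccc(C#N)cc2)n1-c1ccccc1`, in this assay gives 153 ug/mL.

Compound 2 holds the only number shown in this assay; the other entry is a limit. Compound 3, `Cc1nnc(SCC(=O)N/N=c2/scc(-c3ccc(C#N)cc3)n2-c2ccccc2)s1`, differs from compound 2 by 5-methyl-1,3,4-thiadiazol-2-yl in place of 4-methyl-4H-1,2,4-triazol-3-yl on a sulfur. For the measured compounds named here, the one measured step, an at least 39-fold higher number from compound 1 to compound 2 (1.59 log units; beyond the scatter), concerned a different exchange at the same sulfur, and its size is open-ended since one side sits at a limit, (the limit of < 3.9 ug/mL in this assay, at which 1 of the 2 values shown sits). Whether exchanging one small aromatic group for another at this position produces a shift of similar size is not shown, and the direction is uncertain. The expectation for compound 3 is a step from compound 2 of a 2.6-fold lower number from compound 2 to compound 3 (0.41 log units; beyond the scatter) in this assay, toward the lower side. Compound 3 is estimated at 60 ug/mL, with a range of 10 ug/mL to 200 ug/mL.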

Compound 3, half-maximal inhibitory concentration: < 3.9 ug/mL
Compound 3: a limit, no number; the forecaster's own chance of this, stated with the estimate: 10%; middle value at least 15-fold (1.18 log units) from the limit.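

The exchange of 4-methyl-4H-1,2,4-triazol-3-yl for 5-methyl-1,3,4-thiadiazol-2-yl on the sulfur gives an at least 39-fold lower number from compound 2 to compound 3 (1.59 log units; beyond the scatter) in this assay. The two groups match in heavy atom count, ring size and hydrogen-bond acceptor count, so among the three compounds shown, the much higher number of compound 2 goes with its particular group and not with the shared core. Compound 1 and compound 3 each stand only at a limit, so the step between them cannot be read: the limit of < 3.9 ug/mL in this assay, at which 2 of the 3 values shown sit.

On these data alone, how far below that limit either compound lies remains open. So does whether an amine or a longer chain ending in a carboxylic acid, placed on the same sulfur, would give a number nearer that of compound 2 or nearer the limit.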